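The source may report more compounds than this note shows. Statements on the series, on what has been measured and on what is new or still open speak of the compounds shown alone.

Compound 1, `COc1ccc(-c2noc(CCCCCCC(=O)NO)n2)cc1`; compound 2, `O=C(CCCCCCc1nc(-c2ccccc2Cl)no1)NO`; compound 3, `O=C(CCCCCCc1nc(-c2cccnc2)no1)NO`.

In an assay on isolated protein for inhibition of histone deacetylase 8 (Homo sapiens), read by fluorescence, with a stated time of 10 min (on this read-out lower numbers stand for stronger inhibition and higher numbers for weaker inhibition), compound 1 gives only a limit of the assay, > 10000 nM. In this assay compound 2 gives 3650 nM, and compound 3 gives 1830 nM. Compound 2 holds the higher of these two numbers, but the step of a 2.0-fold lower number from compound 2 to compound 3 (0.30 log units; within the scatter) is within the scatter, so the two cannot be ordered. The remaining result, that of compound 1, is a limit (the limit of > 10000 nM in this assay, at which 1 of the 3 values shown sits).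

The next compound, compound 4, `Nc1ccccc1NC(=O)CCCCCCc1nc(-c2ccccc2Cl)no1`, differs from compound 2 in one place: 2-aminophenyl in place of hydroxy on an amide-type nitrogen. For the measured compounds named here, no measured step touches this end of the chain; the only step available, a 2.0-fold lower number from compound 2 to compound 3 (0.30 log units; within the scatter), changes the aromatic group on the other end. The size and direction of the new step therefore cannot be read from the measured compounds. As an estimate, compound 4 is expected to give 20000 nM in this assay, between 4000 nM and 100000 nM, which would mean an expected step of a 5.5-fold higher number from compound 2 to compound 4 (0.74 log units; beyond the scatter).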

Compound 4, half-maximal inhibitory concentration: > 10000 nM
Compound 4: only a limit was reported; the forecaster's own chance of this, stated with the estimate: 60%; the middle value lies beyond the limit too.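

For the compounds shown here, the only earlier step changed an aromatic group and stayed within the scatter, so it showed nothing about the amide-type nitrogen. Here, 2-aminophenyl in place of hydroxy on that nitrogen gives an at least 2.7-fold higher number from compound 2 to compound 4 (0.43 log units; beyond the scatter), the first step in this assay that lies beyond the scatter, so inhibition is sensitive to this change. Compound 4 gives > 10000 nM, which is a limit of the assay and not a number, so only a smallest possible size is known for this step: the limit of > 10000 nM in this assay, at which 2 of the 4 values shown sit.

The compounds shown leave open how other groups on this nitrogen would read, such as a methyl group or a 2-hydroxyphenyl group, and whether a carboxylic acid in place of the whole hydroxyamide would fare differently. They also leave open whether a longer chain would alter the size of this step.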